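The source may report more compounds than this note shows. Statements on the series, on what has been measured and on what is new or still open speak of the compounds shown alone.

Compound 1 `O=C(NCCCCC(c1ccc(F)cc1)c1ccc(F)cc1)Nc1ccc(Cl)cc1` carries chloro on an aromatic carbon, and in a functional assay on MDA-MB-231 cells (Homo sapiens) for cytotoxicity, read by MTT assay, with a stated time of 48 h (a higher number here means a weaker inhibitor, a lower number a stronger inhibitor), compound 1 gives 7680 nM. Compound 2 `Nc1ccc(NC(=O)NCCCCC(c2ccc(F)cc2)c2ccc(F)cc2)cc1` has amino in place of that chloro. In this assay compound 2 gives > 20000 nM, which is a limit of the assay and not a number. Going by the values given here, the only measured step, an at least 2.6-fold higher number from compound 1 to compound 2 (0.41 log units; beyond the scatter), rests on (the limit of > 20000 nM in this assay, at which 1 of the 2 values shown sits), so its full size is not known. Compound 3 `O=C(NCCCCC(c1ccc(F)cc1)c1ccc(F)cc1)Nc1cccc(Cl)c1` differs from compound 2 by 3-chlorophenyl in place of 4-aminophenyl on an amide-type nitrogen. Chloro returns, now as 3-chlorophenyl, while amino leaves, so the step from compound 1 to compound 2 bears on this change in reverse; a decrease of at least comparable size, back toward the value of compound 1, is expected, an at least 2.2-fold lower number from compound 2 to compound 3 (0.34 log units; beyond the scatter). Compound 3 is therefore estimated at 9000 nM, with a range from 4000 nM to 20000 nM.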

Compound 3, half-maximal inhibitory concentration: 5070 nM
The estimate for compound 3 lay 1.8-fold (0.25 log units) above the measured number; measured number inside the range.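

In this assay, 3-chlorophenyl and 4-chlorophenyl on the amide-type nitrogen cannot be told apart: a 1.5-fold lower number from compound 1 to compound 3 (0.18 log units; within the scatter). The gap to 4-aminophenyl therefore appears with chloro in either of the two ring positions shown, with an at least 3.9-fold lower number from compound 2 to compound 3 (0.59 log units; beyond the scatter) alongside the step already seen from the 4-chlorophenyl compound. The full size of that gap stays unknown because compound 2 sits at a limit of the assay and not at a number: the limit of > 20000 nM in this assay, at which 1 of the 3 values shown sits.

Open, as far as these compounds go, is whether chloro itself matters or whether any group other than amino would read the same, which methyl or a carboxylic acid in its place would address. Also open, from the compounds shown here alone, is whether the same reading holds with a longer chain in the shared core.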